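Compound 4: (Oxolan-3-yl)oxy Replaces Oxolan-3-yl on the Carbonyl

The source may report more compounds than this note shows. Statements on the series, on what has been measured and on what is new or still open speak of the compounds shown alone.

Compound 3 `Cc1cc(NC(=O)C2CCOC2)nn1Cc1cc(Cl)ccc1OCc1ccccc1` stands at the top of the numbers shown. In a physicochemical assay for lipophilicity, at pH 7.4 (on this read-out lower numbers stand for lower lipophilicity and higher numbers for higher lipophilicity), compound 3 gives > 3.7, which is a limit of the assay and not a number. Compound 1 `Cc1cc(C(=O)NC(C)C)nn1Cc1cc(Cl)ccc1OCc1ccccc1` also reaches a limit, giving > 3.7 in this assay. Within the data shown here, compound 2 `Cc1cc(C(=O)Nc2cccc(F)c2)nn1Cc1cc(Cl)ccc1OCc1ccccc1` gives 2.8 in this assay, the only full number of the three, and the limit of > 3.7 in this assay, at which 2 of the 3 values shown sit, shapes how the steps read: a number at least 0.90 log units lower from compound 1 to compound 2 (beyond the scatter), a number at least 0.90 log units higher from compound 2 to compound 3 (beyond the scatter), while a step that the two limits leave unreadable from compound 1 to compound 3.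

Compound 4 `Cc1cc(NC(=O)O[C@H]2CCOC2)nn1Cc1cc(Cl)ccc1OCc1ccccc1` differs from compound 3 in one place: (oxolan-3-yl)oxy in place of oxolan-3-yl on a carbonyl carbon. Among the measured compounds shown here, none of the measured steps touches the carbonyl carbon in this way, so they give no direct guide to the size of the change; they only show that compound 3 sits at a limit, leaving its true distance from compound 2 open. The step is therefore expected to be small or within the scatter, and compound 4 is estimated at 3.6, between 3 and 4.2, an expected change of a number at least 0.10 log units lower from compound 3 to compound 4 (that floor lies within the scatter).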

Compound 4, distribution coefficient: 2.7
Compound 4: the middle estimate sits 0.90 log units above what was measured, and the stated range ends above it.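

In this assay, the first change shown on this carbonyl carbon is far from silent: (oxolan-3-yl)oxy in place of oxolan-3-yl gives a number at least 1.00 log units lower from compound 3 to compound 4 (beyond the scatter). A full number is thus reached without a 3-fluorophenyl group, the step to the earlier full number reading a number 0.10 log units lower from compound 2 to compound 4 (within the scatter), while the step from the isopropyl amide reads a number at least 1.00 log units lower from compound 1 to compound 4 (beyond the scatter). The two steps that start from a limit give only a floor on their size, and their true size stays unknown because of this: the limit of > 3.7 in this assay, at which 2 of the 4 values shown sit.

The compounds shown leave open whether an ethoxy chain or a (pyrrolidin-3-yl)oxy group on the same carbonyl carbon would give a step of like size. They also leave open whether the opposite stereocentre in the (oxolan-3-yl)oxy group would read the same.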